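Urea analogue with chloro in place of trifluoromethyl

This account rests on a few compounds, and the source may have more. Where it says the series, first, only, none or still open, it means among the compounds named here.

Measured so far:
compound 1 `COc1cc(Cl)cc(-c2nn(-c3cccc(NC(=O)c4ccc(Cl)c(Cl)c4)c3)cc2-c2ccncc2)c1`: 57.7%
compound 2 `O=C(Nc1cccc(-n2cc(-c3ccncc3)c(-c3cc(O)cc(Cl)c3)n2)c1)Nc1ccc(Cl)c(C(F)(F)F)c1`: 13.4%

Among the compounds with values here, in a functional assay on MCF7 cells (Homo sapiens) for inhibition, read by sulforhodamine B assay, with a stated time of 48 h, tested at 10 uM (on this read-out lower numbers stand for a stronger effect and higher numbers for a weaker effect at the one concentration tested), compound 2 gives the lowest of the two numbers, and its only neighbour, compound 1, sits higher by a gap that is beyond the scatter. Within the data shown here, no pair of measured compounds differs in just one place, so nothing measured yet shows how a single change on this shared core moves the read-out.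

Compound 3 `O=C(Nc1cccc(-n2cc(-c3ccncc3)c(-c3cc(O)cc(Cl)c3)n2)c1)Nc1ccc(Cl)c(Cl)c1` is the next compound for this assay. Against compound 2 the change is chloro in place of trifluoromethyl on an aromatic carbon: the trifluoromethyl leaves and a chloro enters on the same aromatic carbon, so that the 4-chloro-3-(trifluoromethyl)phenyl becomes a 3,4-dichlorophenyl. The expected step of a number 8.6 percentage points higher from compound 2 to compound 3 (within the scatter) is small, in the direction of a slightly higher number, and may well stay within the scatter. Compound 3 is therefore estimated at 22%, within a range from 8% to 45%.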

Compound 3, a percentage reported as activity, at one concentration (the size of the read-out at that concentration, not a potency): 2.74%
Beside the measured number, compound 3's estimate is 19.3 percentage points above it; the measured number lies below the stated range.
By their numbers in this assay, from the lowest: compound 3; then compound 2; then compound 1.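

In this assay, the step of a number 10.7 percentage points lower from compound 2 to compound 3 (beyond the scatter) gives the series its first comparison of compounds that differ in one place. On this aromatic carbon, ortho to a chloro group, trifluoromethyl is not required for a low number: the 3,4-dichlorophenyl urea goes lower than the 4-chloro-3-(trifluoromethyl)phenyl urea, by a modest step beyond the scatter. Nothing available explains this step.

This single exchange does not show how the read-out responds to other groups on the same carbon, such as hydrogen, fluoro, methyl or nitrile. It also leaves open whether chloro in place of trifluoromethyl would move the number the same way on another core or at a concentration other than the one tested.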